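The source may report more compounds than this note shows. Statements on the series, on what has been measured and on what is new or still open speak of the compounds shown alone.

Within the data shown here, in a functional assay on OVCAR-4 cells (Homo sapiens) for cytotoxicity, read by sulforhodamine B assay, with a stated time of 48 h (on this read-out higher numbers stand for weaker inhibition of growth and lower numbers for stronger inhibition of growth), compound 1 (`COc1cc(C(=O)c2ccc(OC)c(O)c2OC)cc(OC)c1O`) gives 100000 nM, the higher of the two numbers so far, and compound 2 (`COc1cc(C(=O)c2ccc3c(c2)oc(=O)n3S(C)(=O)=O)cc(OC)c1OC`) gives 22300 nM, a gap beyond the scatter. Compound 3 (`COc1ccc(C(=O)c2cc(OC)c(OC)c(OC)c2)c(OC)c1O`) differs from compound 1 in one place: methyl in place of hydrogen on an oxygen on an aromatic ring, turning a hydroxy into a methoxy. Among the measured compounds shown here, no measured pair shows this change. The new methoxy gives compound 3 a pattern also seen in compound 2 at 22300 nM, so a step beyond the scatter towards stronger inhibition of growth is expected. The estimated change is a 13-fold lower number from compound 1 to compound 3 (1.10 log units; beyond the scatter). For compound 3 the expected value is 8000 nM, within a range of 500 nM to 60000 nM.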

Compound 3, concentration for 50% growth inhibition: 73 nM
For compound 3 the middle estimate is 110-fold (2.04 log units) above the measured one; measured number outside the range, below it.
By their numbers in this assay, from the lowest: compound 3; then compound 2; then compound 1.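

Turning this one hydroxy into a methoxy gives a 1400-fold lower number from compound 1 to compound 3 (3.14 log units; beyond the scatter) in this assay and is large. Among these compounds, this is the first pair here that differs in one place, so it shows that a single methyl on this oxygen, on an otherwise shared structure, can by itself decide much of the growth inhibition. Nothing at hand gives a reason for a step of this size. Still open, from the compounds shown here alone, is whether a longer chain on this oxygen, such as ethyl, would hold the low number. Also open, going by these compounds, is what an amine in place of this hydroxy would do.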